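The source may report more compounds than this note shows. Statements on the series, on what has been measured and on what is new or still open speak of the compounds shown alone.

Three compounds measured in an assay on HEK293 cells for positive allosteric modulation of metabotropic glutamate receptor 2 (Rattus norvegicus), read by thallium flux, with a stated time of 2.5 min (on this read-out higher numbers stand for larger maximal responses and lower numbers for smaller maximal responses), share a linker between two aromatic cores and differ in the ketone side chain and in the substitution of the acid-bearing core. Compound 1, `COc1cc(C(=O)O)ccc1OCCCCOc1ccc(C(=O)CC(C)C)c(O)c1C`, carries an isobutylcarbonyl group; in this assay compound 1 gives 85.7%. Compound 2, `CCC(=O)c1ccc(OCCCCOc2cc(C(=O)O)ccc2OC)c(C)c1O`, carries a propanoyl group; in this assay compound 2 gives 72.6%. Compound 3, `COc1ccc(C(=O)O)cc1OCCCCOc1ccc(C(C)=O)c(O)c1C`, carries an acetyl group; in this assay compound 3 gives 70.7%. The difference between the core of compound 1 and the core of compound 3 is not broken down here.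

Compound 2 differs from compound 3 by methyl in place of hydrogen on a saturated chain carbon bound to a carbonyl carbon, and this step gave a number 1.9 percentage points higher from compound 3 to compound 2 (within the scatter). Compound 4, `COc1cc(C(=O)O)ccc1OCCCCOc1ccc(C(=O)CC(C)(C)C)c(O)c1C`, has not been measured; it differs from compound 1 by methyl in place of hydrogen on a saturated chain carbon bound to three saturated chain carbons. Within the data shown here, this is the same kind of change as the one from compound 3 to compound 2, but not the same: there the methyl enters on a saturated chain carbon bound to a carbonyl carbon, here on a saturated chain carbon bound to three saturated chain carbons.

Because the earlier step of a number 1.9 percentage points higher from compound 3 to compound 2 (within the scatter) stayed within the scatter, the step from compound 1 to compound 4 in this assay is expected to be small as well, about a number 3.7 percentage points lower from compound 1 to compound 4 (within the scatter), with the second occurrence resting on a single earlier example at a different place. For compound 4 in this assay a response of about 82% is estimated, between 62% and 98%.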

Compound 4, largest response reached (reported as percent of maximum), in percent of the reference or control that the assay uses: 98.6%
Compound 4: the middle estimate sits 16.6 percentage points below what was measured, and the stated range ends below it.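

In this assay, the change from isobutylcarbonyl to neopentylcarbonyl gave a number 12.9 percentage points higher from compound 1 to compound 4 (beyond the scatter), so this methyl, entering on a saturated chain carbon bound to three saturated chain carbons, moved the maximal response by more than repeated measurements would. Set beside the earlier step, the two results cannot be told apart, even though only the newer one lies beyond the scatter when read alone: the same change on two cores in this assay, a number 1.9 percentage points higher (within the scatter) from compound 3 to compound 2 and a number 12.9 percentage points higher (beyond the scatter) from compound 1 to compound 4, 11 percentage points apart, within the scatter of two such steps. Among these compounds, this shows that the change has not behaved differently on the two cores, but it does not show that the change carries over unaltered, since there are only two pairs and the methyl enters at a different place in each, so any influence of the core cannot be separated from that of the place.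

The compounds shown carry only open-chain ketone side chains, leaving open what a cyclopropyl or phenyl group on the carbonyl, or a longer chain, would do to the response in this assay. They also leave open whether a tetrazole or an amide could stand in for the carboxylic acid on the acid-bearing core.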